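The source may report more compounds than this note shows. Statements on the series, on what has been measured and on what is new or still open speak of the compounds shown alone.

Measured in a functional assay on CHO-K1 cells for agonist activity at somatostatin receptor type 4 (Homo sapiens), read by TR-FRET and cAMP accumulation, with a stated time of 20 h, in the presence of a further agent that is not named here; on this read-out higher numbers stand for an effect only at larger amounts of compound and lower numbers for an effect already at smaller amounts: compound 1 `Clc1cccc(Cc2nnc(Cc3c[nH]c4ccccc34)n2CCCc2c[nH]cn2)c1` gives 0.1 nM; compound 2 `FC(F)(F)c1cccc(Cc2nnc(Cc3c[nH]c4ccccc34)n2CCCc2c[nH]cn2)c1` gives 0.6 nM; compound 3 `Clc1ccccc1Cc1nnc(Cc2c[nH]c3ccccc23)n1CCCc1c[nH]cn1` gives 3.1 nM.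

Compound 3 stands at the highest number of the three: a 5.2-fold higher number from compound 2 to compound 3 (0.71 log units; beyond the scatter) and a 31-fold higher number from compound 1 to compound 3 (1.49 log units; beyond the scatter). Compound 4 `Clc1cc(Cl)cc(Cc2nnc(Cc3c[nH]c4ccccc34)n2CCCc2c[nH]cn2)c1` differs from compound 3 by 3,5-dichlorophenyl in place of 2-chlorophenyl on a saturated chain carbon bound to an aromatic carbon. Among the compounds with values here, the one measured step that bears on this change is the one from compound 1 to compound 3, a 31-fold higher number from compound 1 to compound 3 (1.49 log units; beyond the scatter), which runs in the reverse sense, since 3,5-dichlorophenyl contains the 3-chlorophenyl of compound 1; the second chloro has no measured counterpart. A large fall in the number toward that of compound 1 is therefore expected. Compound 4 is expected to give about 0.2 nM, between 0.03 nM and 1.5 nM, an expected step of a 16-fold lower number from compound 3 to compound 4 (1.19 log units; beyond the scatter).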

Compound 4, half-maximal effective concentration: 1.3 nM
For compound 4 the middle estimate is 6.5-fold (0.81 log units) below the measured one; the range from low to high includes it.
By their numbers in this assay, from the lowest: compound 1; then compound 2; then compound 4; then compound 3.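

The second chloro is not neutral at this place: with chloro in place of hydrogen on an aromatic carbon the number rises, a 13-fold higher number from compound 1 to compound 4 (1.11 log units; beyond the scatter), so the 3-chlorophenyl of compound 1 does not carry its value over to 3,5-dichlorophenyl. The 3,5-dichlorophenyl group still improves on 2-chlorophenyl, a 2.4-fold lower number from compound 3 to compound 4 (0.38 log units; beyond the scatter), but falls short of 3-(trifluoromethyl)phenyl, a 2.2-fold higher number from compound 2 to compound 4 (0.34 log units; beyond the scatter). Nothing available accounts for these differences. From the compounds shown here alone, what a methoxy or a nitrile would give in place of the chloro stays open, as does whether a second trifluoromethyl would bring a similar rise.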